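The compounds below may be only part of what the source reports. "The series", "measured", "known", "first", "only" and "open" are said of these compounds alone.

Measured compounds:
- compound 1 `CC1(C)S[C@@H]2/C(=C\C(=O)c3ccc4ccccc4c3)C(=O)N2[C@H]1C(=O)OC(c1ccccc1)c1ccccc1`: 19500 nM
- compound 2 `CC1(C)S[C@@H]2C/C(=C\C(=O)c3ccccc3)C(=O)N2[C@H]1C(=O)OC(c1ccccc1)c1ccccc1`: 73300 nM

Both compounds were tested in a functional assay on OE19 cells (Homo sapiens) for cytotoxicity, read by MTT assay, with a stated time of 48 h; a lower number here means a stronger inhibitor, a higher number a weaker inhibitor. Compound 1 gives 19500 nM, and compound 2 gives 73300 nM. Of the two numbers, compound 1 has the lowest; the nearest one belongs to compound 2, whose number is higher by a gap beyond the scatter. Going by the values given here, no pair differing in one place has been measured, so no single step stands behind these two values.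

The next compound to be measured is compound 3 `CC1(C)S[C@@H]2/C(=C\C(=O)OCc3ccccc3)C(=O)N2[C@H]1C(=O)OC(c1ccccc1)c1ccccc1`. It differs from compound 1 in one place: benzyloxy in place of naphthalen-2-yl on a carbonyl carbon. Among the compounds with values here, nothing among the measured compounds speaks directly to this change, so any expectation rests on compound 1 alone and on the wide spread between compound 1 and compound 2.

In this assay the step of a 1.8-fold higher number from compound 1 to compound 3 (0.25 log units; within the scatter) is expected to be modest and towards a higher number, though a result within the scatter would not surprise. Compound 3 is therefore estimated at 35000 nM, with a range from 12000 nM to 100000 nM.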

Compound 3, half-maximal inhibitory concentration: 8200 nM
Estimate against measurement, compound 3: 4.3-fold (0.63 log units) above, outside the stated range (below it).
By their numbers in this assay, from the lowest: compound 3; then compound 1; then compound 2.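

In this assay, the change from (naphthalen-2-yl)carbonyl to benzyloxycarbonyl on the double-bonded chain carbon gives a 2.4-fold lower number from compound 1 to compound 3 (0.38 log units; beyond the scatter), a modest step that lies beyond the scatter. Going by these compounds alone, this is the first sign that the group on this carbonyl carbon can be exchanged on the core of compound 1 without losing activity, and that the two six-membered aromatic rings of naphthalen-2-yl are not required for a number at this level: benzyloxy, with one such ring and an oxygen as hydrogen-bond acceptor, gives the lower number. No measurement of any property or mechanism accompanies this step, so the data give no explanation for it.

The compounds shown leave open whether the oxygen, the loss of one aromatic ring or the different spacing of the ring accounts for the step, as all of these change together in this single exchange. Also open, from the compounds shown here alone, is how this position responds to groups such as methoxy, a benzylamino group or a free carboxylic acid on the same carbonyl carbon, which would help to separate these contributions.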